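This account rests on a few compounds, and the source may have more. Where it says the series, first, only, none or still open, it means among the compounds named here.

Working notes on the series. For the measured compounds named here, in a functional assay on MCF7 cells (Homo sapiens) for antiproliferative activity, read by MTT assay, with a stated time of 48 h (on this read-out lower numbers stand for stronger inhibition and higher numbers for weaker inhibition), compound 1 `CC(=O)OC/C1=C/C[C@](C)(CCC=C(C)C)/C=C/[C@@H](OC(=O)C=C(C)C)[C@](C)(OC(C)=O)/C=C/C1=O` gives 3990 nM and compound 2 `CC(C)=CCC[C@]1(C)/C=C/[C@@H](OC(=O)C=C(C)C)[C@](C)(O)/C=C/C(=O)/C(C=O)=C\C1` gives 12600 nM; compound 2 thus gives the highest of the two numbers, with compound 1 as its only neighbour at a lower number, beyond the scatter. Compound 3 `COCOC/C1=C/C[C@](C)(CCC=C(C)C)/C=C/[C@@H](OC(=O)C=C(C)C)[C@](C)(O)/C=C/C1=O` is not yet measured; it differs from compound 2 by (methoxymethoxy)methyl in place of formyl on a double-bonded ring carbon. Going by the values given here, no measured pair covers this change, so the expected step from compound 2 to compound 3 is a 2.5-fold lower number from compound 2 to compound 3 (0.40 log units; beyond the scatter), a drop toward the number of compound 1. Compound 3 is estimated at 5000 nM, in the range 1500 nM to 16000 nM.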

Compound 3, half-maximal inhibitory concentration: 3120 nM
For compound 3 the middle estimate is 1.6-fold (0.20 log units) above the measured one, within the range that was stated.
By their numbers in this assay, from the lowest: compounds 3 and 1 (each within the scatter of the next); then compound 2.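

For the compounds shown here, replacing formyl with (methoxymethoxy)methyl on a double-bonded ring carbon gives a 4.0-fold lower number from compound 2 to compound 3 (0.61 log units; beyond the scatter) in this assay and is the first single-place reading at this position. Formyl is therefore not required there for antiproliferative activity, and this larger, non-carbonyl group is accepted. No supporting data bear on what lies behind this step.

Still open, going by these compounds, is whether the lower number comes from losing formyl or from gaining the ether chain. Hydroxymethyl or a carboxylic acid on the same carbon would address that question.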